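Vinyl sulfone ketones: growth inhibition in prostate cells

The source may report more compounds than this note shows. Statements on the series, on what has been measured and on what is new or still open speak of the compounds shown alone.

Measured so far:
compound 1, `O=C(/C(=C\c1ccc(F)c([N+](=O)[O-])c1)S(=O)(=O)c1ccc(Br)cc1)c1ccc(Br)cc1`, 25000 nM
compound 2, `CCOc1cc(/C=C(\C(=O)c2ccc(Cl)cc2)S(=O)(=O)Cc2ccc(Cl)cc2)ccc1O`, 10000 nM

In a functional assay on DU-145 cells (Homo sapiens) for inhibition, read by trypan blue exclusion, with a stated time of 96 h (a lower number here means a stronger inhibitor of growth, a higher number a weaker inhibitor of growth), compound 2 gives the lower of the two numbers, and the gap to compound 1 lies beyond the usual scatter. Compound 3, `Cc1cc(C)cc(/C=C(\C(=O)c2ccc(Cl)cc2)S(=O)(=O)Cc2ccc(Cl)cc2)c1`, is not yet measured; it carries 3,5-dimethylphenyl in place of 3-ethoxy-4-hydroxyphenyl on a double-bonded chain carbon bound to a double-bonded chain carbon. Going by the values given here, no step of this kind has been measured, so the expectation rests on compound 2 alone. The expected change is a 1.2-fold higher number from compound 2 to compound 3 (0.08 log units; within the scatter), within the scatter, with no clear direction. Compound 3 is therefore estimated at 12000 nM, in the range 4000 nM to 40000 nM.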

Compound 3, concentration for 50% growth inhibition: 1000 nM
The estimate for compound 3 lay 12-fold (1.08 log units) above the measured number; the whole stated range lies above it.
By their numbers in this assay, from the lowest: compound 3; then compound 2; then compound 1.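

At this place, on a double-bonded chain carbon bound to a double-bonded chain carbon, the choice of aryl group clearly moves the result in this assay: 3,5-dimethylphenyl in place of 3-ethoxy-4-hydroxyphenyl gives a 10-fold lower number from compound 2 to compound 3 (1.00 log units; beyond the scatter). The entering group has 0 hydrogen-bond donors and 0 hydrogen-bond acceptors, so neither is needed for the lower number in compound 3. No evidence in hand accounts for this step.

Still open, on these data alone, is whether the gain comes from adding the methyl groups or from losing the ethoxy and hydroxy groups. As far as these compounds go, how an amine or a carboxylic acid on this phenyl group would read also remains unknown.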